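A few compounds are considered here, and "the series" means these few. Any claim that something is new, unique, unknown or untested is made for them only; others in the source may bear on it.

Working notes on the series. In a functional assay on 4T1 cells (Homo sapiens) for cytotoxicity, read by MTT assay, with a stated time of 48 h (on this read-out higher numbers stand for weaker inhibition and lower numbers for stronger inhibition), compound 3 `Cn1c(/C=C2/C(=O)Nc3ccc(F)cc32)nc2ccccc21` gives 29600 nM and compound 1 `CC(C)n1c(/C=C2/C(=O)Nc3ccc(F)cc32)nc2ccccc21` gives 25800 nM. The change between them, methyl in place of isopropyl on an aromatic nitrogen, is a 1.1-fold higher number from compound 1 to compound 3 (0.06 log units; within the scatter), so compound 3 stands level with compound 1. Compound 2 `Cn1c(/C=C2/C(=O)Nc3ccc(Br)cc32)nc2ccccc21` returns only a limit, > 50000 nM. Among the compounds with values here, no compound in this small set therefore has a measured value clearly apart from compound 3.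

The next analogue is compound 4 `Cn1c(/C=C2/C(=O)Nc3ccc(Cl)cc32)nc2ccccc21`, with chloro in place of fluoro on an aromatic carbon, meta to a fused ring and para to a fused ring. The step from compound 1 lies on the aromatic nitrogen and says little about this change. The relevant comparison is at the same carbon, an at least 1.6-fold lower number from compound 2 to compound 3 (0.22 log units; that floor lies within the scatter). That step gives only a floor, and the floor itself does not clear the scatter.

With chloro untested, a small move toward a higher number is expected, not clearly beyond the scatter. The expected step is a 1.1-fold higher number from compound 3 to compound 4 (0.06 log units; within the scatter). For compound 4 the estimated value in this assay is 34000 nM, with an expected range of 18000 nM to 50000 nM.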

Compound 4, half-maximal inhibitory concentration: 43600 nM
Estimate against measurement, compound 4: 1.3-fold (0.11 log units) below, and the stated range covers the measured number.
By their numbers in this assay, from the lowest: compounds 1, 3 and 4 (each within the scatter of the next). At a limit, above all of these: compound 2.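

At this carbon, meta to a fused ring and para to a fused ring, fluoro and chloro can now be compared directly in this assay (a 1.5-fold higher number from compound 3 to compound 4 (0.17 log units; within the scatter)), and that step does not separate compound 3 from compound 4. The earlier compounds shown here offered only a floor for a change at this carbon; the comparison with bromo again gives only a floor (an at least 1.1-fold lower number from compound 2 to compound 4 (0.05 log units; that floor lies within the scatter)), so it adds no measured size for that change. Going by these compounds, that comparison stays open-ended because compound 2 is held at a limit, not a number: the limit of > 50000 nM in this assay, at which 1 of the 4 values shown sits.

The compounds shown leave open whether any other group on this aromatic carbon, such as methoxy, an amine or a carboxylic acid, would give a step beyond the scatter, since fluoro and chloro, the two substituents here with measured values on a methyl-bearing aromatic nitrogen, do not. They also leave open whether the comparison of chloro with fluoro would read the same with isopropyl on the aromatic nitrogen, where only fluoro is shown.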